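Swapping the Isopropyl for a Phenoxyethyl Chain

The source may hold more compounds than are shown below. What is called first, only, known or untested is meant among the compounds shown, and "the series" means these compounds.

Measured compounds:
compound 1, `CCCCCN(Cc1ccc(C(=O)NO)cc1)c1ncc(-c2ccc(C)cc2)s1`: 7020 nM
compound 2, `Cc1ccc(-c2cnc(N(Cc3ccc(C(=O)NO)cc3)CC(C)C)s2)cc1`: 7420 nM
compound 3, `CCCCCCCCN(Cc1ccc(C(=O)NO)cc1)c1ncc(-c2ccc(C)cc2)s1`: 8760 nM

These three compounds were tested in a functional assay on HepG2 cells (Homo sapiens) for antiproliferative activity, read by MTT assay, with a stated time of 48 h; a higher number here means a weaker inhibitor of growth, a lower number a stronger inhibitor of growth. Compound 2 sits second highest of the three numbers, but the steps of a 1.1-fold higher number from compound 1 to compound 2 (0.02 log units; within the scatter) and a 1.2-fold higher number from compound 2 to compound 3 (0.07 log units; within the scatter) both lie within the scatter, as does a 1.2-fold higher number from compound 1 to compound 3 (0.10 log units; within the scatter), so the three cannot be put in order. Compound 4, `Cc1ccc(-c2cnc(N(CCCOc3ccccc3)Cc3ccc(C(=O)NO)cc3)s2)cc1`, differs from compound 2 in one place: 2-phenoxyethyl in place of isopropyl on a saturated chain carbon bound to a nitrogen on an aromatic ring. The three measured steps each exchange one chain for another on that same carbon, and together they show that going among butyl, isopropyl and heptyl there left this assay unmoved. They bear on the new change only loosely, since none of them brings in a ring or an oxygen, so the range is kept wide. On that basis no step beyond the scatter is expected for a 1.1-fold lower number from compound 2 to compound 4 (0.03 log units; within the scatter). Compound 4 is therefore estimated at 7000 nM, within the range 2500 nM to 20000 nM.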

Compound 4, concentration for 50% growth inhibition: 23400 nM
Compound 4: middle estimate off by 3.3-fold (0.52 log units), on the low side, outside the stated range (above it).
By their numbers in this assay, from the lowest: compounds 1, 2 and 3 (each within the scatter of the next); then compound 4.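

In this assay, the saturated chain carbon bound to a nitrogen on an aromatic ring turns out not to accept every chain equally: 2-phenoxyethyl in place of isopropyl gives a 3.2-fold higher number from compound 2 to compound 4 (0.50 log units; beyond the scatter), and the other two comparisons agree, with a 3.3-fold higher number from compound 1 to compound 4 (0.52 log units; beyond the scatter) and a 2.7-fold higher number from compound 3 to compound 4 (0.43 log units; beyond the scatter). For the compounds shown here, the chains made only of carbon stayed within the scatter of one another, so the phenoxy-bearing chain is the first here to shift growth inhibition, and it shifts it modestly towards the weaker side. Nothing available explains this shift.

The change brings in an oxygen and a ring together, so these compounds cannot show which of the two goes with the weaker growth inhibition. A chain with the ring but no oxygen, such as phenylpropyl, or with the oxygen but no ring, such as methoxyethyl, remains an open case.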